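A few compounds are considered here, and "the series" means these few. Any claim that something is new, unique, unknown or untested is made for them only; others in the source may bear on it.

Measured in a functional assay on HeLa cells (Homo sapiens) for antiproliferative activity, read by MTT assay, with a stated time of 48 h; a lower number here means a stronger inhibitor, a higher number a weaker inhibitor:
- compound 1 `COc1ccc(N(C)c2ccnc(Cl)n2)cc1`: 917 nM
- compound 2 `COc1ccc(N(C)c2ccnc(Cl)n2)cc1F`: 241 nM
- compound 3 `COc1ccc(N(C)c2ccnc(Cl)n2)cc1[N+](=O)[O-]`: 4730 nM

Compound 3 has the highest number of the three, and its steps to both others lie beyond the scatter. Compound 4 `COc1ccc(N(C)c2ccnc(Cl)n2)cc1O` carries hydroxy in place of nitro on an aromatic carbon, ortho to a methoxy group: hydroxy in place of nitro on an aromatic carbon. Within the data shown here, two measured steps bear on this change: nitro gave a 5.2-fold higher number from compound 1 to compound 3 (0.71 log units; beyond the scatter), a modest step, and a 20-fold higher number from compound 2 to compound 3 (1.29 log units; beyond the scatter), a large one. Among the measured compounds shown here, no hydroxy compound has been measured, so a modest step to a lower number is expected in this assay. The estimated step is a 4.7-fold lower number from compound 3 to compound 4 (0.67 log units; beyond the scatter). For compound 4 the expected value is 1000 nM, within an estimated range of 280 nM to 3800 nM.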

Compound 4, half-maximal inhibitory concentration: 96 nM
The estimate for compound 4 lay 10-fold (1.02 log units) above the measured number; the whole stated range lies above it.
By their numbers in this assay, from the lowest: compound 4; then compound 2; then compound 1; then compound 3.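

In this assay hydroxy on this aromatic carbon, ortho to a methoxy group, gives a lower number than nitro (a 49-fold lower number from compound 3 to compound 4 (1.69 log units; beyond the scatter)), hydrogen (a 9.6-fold lower number from compound 1 to compound 4 (0.98 log units; beyond the scatter)) and also fluoro (a 2.5-fold lower number from compound 2 to compound 4 (0.40 log units; beyond the scatter)). Fluoro therefore no longer marks the lowest number reached at this position, and the change from nitro to hydroxy is the largest step among these four compounds. No measurement shown here explains this order. Going by these compounds, whether an amine or a carboxylic acid on this carbon would fall nearer hydroxy or nitro stays open. So does whether this order holds in other cell lines.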